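The source may report more compounds than this note shows. Statements on the series, on what has been measured and on what is new or still open speak of the compounds shown alone.

Measured in an ADME assay on a cell-free system (plasma, Homo sapiens) for metabolic stability, at 37 degrees C; on this read-out higher numbers stand for a longer-lived compound and lower numbers for a shorter-lived compound:
Compound 1 `CCC/N=C1\S/C(=C\c2ccc(C(=O)OCCCO)cc2)C(=O)N1c1ccccc1O`: > 3 h, a limit and not a number
Compound 2 `CCC/N=C1\S/C(=C\c2ccc(C(=O)OCC(O)CO)cc2)C(=O)N1c1ccccc1O`: > 3 h, a limit and not a number
Compound 3 `CCC/N=C1\S/C(=C\c2ccc(C(=O)OCC3COC(=O)O3)cc2)C(=O)N1c1ccccc1O`: 1.02 h

Of the three, only compound 3 gives a real number. The measured steps place it low in the set: an at least 2.9-fold lower number from compound 1 to compound 3 (0.46 log units; beyond the scatter) and an at least 2.9-fold lower number from compound 2 to compound 3 (0.46 log units; beyond the scatter). Both are steps in which 2-oxo-1,3-dioxolan-4-yl enters. The remaining step, a step that the two limits leave unreadable from compound 1 to compound 2, offers no size to use.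

Compound 4 `CCC/N=C1\S/C(=C\c2ccc(CCC(=O)OC)cc2)C(=O)N1c1ccccc1O` has not been measured yet. Its change from compound 3 is 2-(methoxycarbonyl)ethyl in place of ((2-oxo-1,3-dioxolan-4-yl)methoxy)carbonyl on an aromatic carbon: 2-(methoxycarbonyl)ethyl replaces ((2-oxo-1,3-dioxolan-4-yl)methoxy)carbonyl on an aromatic carbon. Compound 4 therefore loses the ring that came with the lower numbers in an at least 2.9-fold lower number from compound 1 to compound 3 (0.46 log units; beyond the scatter) and an at least 2.9-fold lower number from compound 2 to compound 3 (0.46 log units; beyond the scatter), so a rise of similar size is expected in this assay. Among the compounds with values here, the entering chain appears in no measured compound, so this expectation is loose. The expected step is a 2.0-fold higher number from compound 3 to compound 4 (0.29 log units; within the scatter). For compound 4 the estimated half-life is 2 h, with an expected range from 0.7 h to 5 h.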

Compound 4, half-life: > 3 h
Compound 4: a limit, no number; the forecaster's own chance of this, stated with the estimate: 40%; middle value at least 1.5-fold (0.17 log units) from the limit.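

In this assay, putting 2-(methoxycarbonyl)ethyl in place of ((2-oxo-1,3-dioxolan-4-yl)methoxy)carbonyl on this aromatic carbon, para to a large group, gives an at least 2.9-fold higher number from compound 3 to compound 4 (0.46 log units; beyond the scatter). Compound 4 gives > 3 h, which is a limit and not a number, and it is the first compound shown to reach that limit with a chain that has no ring and no carbonyl joined directly to the aromatic carbon. The steps from compound 1 and from compound 2 to compound 4 cannot be read: the limit of > 3 h in this assay, at which 3 of the 4 values shown sit.

Going by these compounds, how compound 1, compound 2 and compound 4 rank against one another therefore stays open, as does how far past the limit each one lies. Also open, on these data alone, is how a carboxylic acid or an amine on the same aromatic carbon would behave in this assay.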